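The source may report more compounds than this note shows. Statements on the series, on what has been measured and on what is new or still open speak of the compounds shown alone.

Working notes on the series. Compound 1 `COc1ccc(F)cc1CNCCCNc1ccnc2cc(Cc3ccc(C#N)cc3)ccc12` is the point of reference. In an ADME assay on HepG2 cells (Homo sapiens) for cytotoxicity, read by luminescence, CellTiter-Glo and ATP content, with a stated time of 72 h (a lower number here means that less compound is needed, a higher number that more compound is needed for the effect), compound 1 gives 6050 nM, the lowest of the three numbers in hand, although the nearest, compound 3 `COc1cccc(CNCCCNc2ccnc3cc(Cc4ccc(C#N)cc4)ccc23)c1O` with 7150 nM, sits within the scatter of it; the furthest, compound 2 `CC(C)Cc1ccc2c(NCCCNCc3ccco3)ccnc2c1`, gives 16000 nM. Among the measured compounds shown here, the only step measured between compounds that differ in one place, a 1.2-fold higher number from compound 1 to compound 3 (0.07 log units; within the scatter), concerns the group on the saturated chain carbon bound to the amine nitrogen, not the aromatic carbon changed here. Compound 4 `COc1ccc(F)cc1CNCCCNc1ccnc2cc(-c3cccc4ccccc34)ccc12` differs from compound 1 as follows: naphthalen-1-yl in place of 4-cyanobenzyl on an aromatic carbon. For the measured compounds named here, no measured step bears on this exchange; compound 2 differs from compound 1 in more than one place and only shows a higher number, so it is no guide. Without direct evidence the step is expected to remain within the scatter, a 1.3-fold lower number from compound 1 to compound 4 (0.13 log units; within the scatter). Compound 4 is therefore expected to give 4500 nM, with a range from 1500 nM to 13500 nM.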

Compound 4, half-maximal effective concentration: 16000 nM
Beside the measured number, compound 4's estimate is 3.6-fold (0.55 log units) below it; measured number above the stated range.
By their numbers in this assay, from the lowest: compounds 1 and 3 (each within the scatter of the next); then compounds 2 and 4 (each within the scatter of the next).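

In this assay, among the compounds shown here, the aromatic carbon of the shared core proves sensitive to the group it carries, with a step beyond the scatter (a 2.6-fold higher number from compound 1 to compound 4 (0.42 log units; beyond the scatter)), whereas the one earlier exchange, on the saturated chain carbon, stayed within it (a 1.2-fold higher number from compound 1 to compound 3 (0.07 log units; within the scatter)). More compound is thus needed for the effect with naphthalen-1-yl than with 4-cyanobenzyl on this carbon. No available data account for this step.

The exchange removes the nitrile and its hydrogen-bond acceptor and brings in a fused aromatic pair of rings in a single move, so the compounds shown leave open which part of the change goes with the higher number. An unsubstituted benzyl or a 4-cyanophenyl group on this aromatic carbon would separate those parts.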